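The source may report more compounds than this note shows. Statements on the series, on what has been measured and on what is new or still open speak of the compounds shown alone.

Compound 1 `C#CCNCCN(C)CCNc1ccnc2cc(Cl)ccc12`: 69000 nM in a functional assay on NCI-H460 cells (Homo sapiens) for antiproliferative activity, read by sulforhodamine B assay, with a stated time of 72 h; on this read-out higher numbers stand for weaker inhibition and lower numbers for stronger inhibition.
Compound 2 `CN(CCNCc1cn(CC(=O)O)nn1)CCNc1ccnc2cc(Cl)ccc12`: > 200000 nM in this assay, which is a limit of the assay and not a number.

Compound 2 thus stands at the limit, (the limit of > 200000 nM in this assay, at which 1 of the 2 values shown sits). Compound 3 `CN(CCNCc1cn(CC(=O)Nc2cccc3ccc(O)cc23)nn1)CCNc1ccnc2cc(Cl)ccc12` differs from compound 2 by (7-hydroxynaphthalen-1-yl)amino in place of hydroxy on a carbonyl carbon. Among the measured compounds shown here, the only measured step, an at least 2.8-fold higher number from compound 1 to compound 2 (0.46 log units; beyond the scatter), concerns a different place in the molecule and does not bear on this change, so no measured step sets a size or direction for it in this assay. Compound 3 is estimated at 120000 nM (range 20000 nM to 400000 nM), an expected step of an at least 1.6-fold lower number from compound 2 to compound 3 (0.22 log units; that floor lies within the scatter).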

Compound 3, half-maximal inhibitory concentration: 67000 nM
Estimate against measurement, compound 3: 1.8-fold (0.25 log units) above; the range from low to high includes it.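

In this assay, among the compounds shown here, the exchange of hydroxy for (7-hydroxynaphthalen-1-yl)amino gives an at least 2.9-fold lower number from compound 2 to compound 3 (0.47 log units; beyond the scatter) at this carbonyl carbon, the first measured change at this position and one towards stronger inhibition. Compound 2 stands only at a limit of the assay, so this step gives a floor and not a full size: the limit of > 200000 nM in this assay, at which 1 of the 3 values shown sits.

The compounds shown leave open whether the naphthalene rings, the amide nitrogen or the ring hydroxy carries the change. A simple phenylamino amide or an unsubstituted naphthalen-1-ylamino amide would separate these parts.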